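This account rests on a few compounds, and the source may have more. Where it says the series, first, only, none or still open, it means among the compounds named here.

The three compounds share one core. Compound 1 `OCc1ccc(NC(=S)Nc2ccc3[nH]ccc3c2)cc1` carries a hydroxymethyl group on its outer ring, compound 2 `S=C(Nc1ccc(Br)cc1)Nc1ccc2[nH]ccc2c1` a bromo group, and compound 3 `O=C(c1ccccc1)c1ccc(NC(=S)Nc2ccc3[nH]ccc3c2)cc1` a benzoyl group. In an ADME assay on cells for inhibition of Amine oxidase [flavin-containing] A (Homo sapiens), read by spectrophotometry (a lower number here means a stronger inhibitor, a higher number a weaker inhibitor), compound 1 is reported as "not active" (no number reported), without a number. In this assay compound 2 gives 5900 nM, which is the only number shown in the set; the remaining entry has no single number against it, so compound 2 stands alone as the reference for what follows.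

The step from compound 2 to compound 3 is benzoyl in place of bromo on an aromatic carbon, para to a large group. For the measured compounds named here, no measured pair shows what such a change does to this assay, so the expectation rests on compound 2 alone. The expected step in this assay, a 1.4-fold higher number from compound 2 to compound 3 (0.13 log units; within the scatter), is small and toward a weaker inhibitor, close to the scatter of repeated runs. On that basis compound 3 is estimated at 8000 nM, with a likely range from 2500 nM to 25000 nM.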

Compound 3, half-maximal inhibitory concentration: "not active" (no number reported)
Compound 3 has no reported number here; there is nothing to compare the estimate with.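

For the compounds shown here, compound 3, like compound 1, has no number in this assay, so no step from compound 2 to compound 3 can be read. The compounds shown leave open how far benzoyl or hydroxymethyl in place of bromo shifts inhibition in this assay; only compound 2 has a number. No evidence shown bears on this result.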